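Receptor binding series: amine substituent exchange on the shared core

The source may hold more compounds than are shown below. What is called first, only, known or untested is meant among the compounds shown, and "the series" means these compounds.

Measured so far in an assay on isolated protein for binding affinity to adenosine receptor A1 (Bos taurus); a lower number here means a stronger inhibitor, a higher number a weaker inhibitor:
compound 1 `OCCNc1nc(-c2ccccc2)nc2c1nnn2Cc1ccccc1`: 38000000 nM
compound 2 `OCCNc1nc(-c2ccccc2)nc2c1nnn2Cc1ccccc1Cl`: 116000000 nM

In this assay compound 1 gives 38000000 nM and stands as the lower of the two numbers recorded; its nearest neighbour is compound 2, which gives 116000000 nM. For the measured compounds named here, the single step between measured compounds is a 3.1-fold higher number from compound 1 to compound 2 (0.48 log units; beyond the scatter), a chloro in place of hydrogen on an aromatic carbon of the benzyl group, a modest move to a higher number.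

Compound 3 `c1ccc(Cn2nnc3c(NC4CCC4)nc(-c4ccccc4)nc32)cc1` is not yet measured. It differs from compound 1 by cyclobutyl in place of 2-hydroxyethyl on a nitrogen on an aromatic ring. Going by the values given here, no measured step touches this nitrogen substituent; the only step recorded concerns a different place on the molecule, so it offers no guide to the direction here. With nothing to lean on, the expectation for this assay is a step of no clear direction, and most likely none beyond the scatter, with a broad range to either side.

Compound 3 is therefore estimated at 35000000 nM with a range from 6000000 nM to 200000000 nM. This estimate corresponds to an expected step of a 1.1-fold lower number from compound 1 to compound 3 (0.04 log units; within the scatter).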

Compound 3, inhibition constant: 5000000 nM
The estimate for compound 3 lay 7.0-fold (0.85 log units) above the measured number, and the stated range ends above it.
By their numbers in this assay, from the lowest: compound 3; then compound 1; then compound 2.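

In this assay, the substituent on the nitrogen on an aromatic ring proves able to shift the number, which the earlier step on the benzyl group could not show: a 7.6-fold lower number from compound 1 to compound 3 (0.88 log units; beyond the scatter). The hydrogen-bond donor and acceptor counted on 2-hydroxyethyl are absent from cyclobutyl, yet the number falls, so in this pair neither is required for the lower value. No measurement at hand bears on the reason for this step.

This single exchange removes the oxygen and introduces the four-membered ring at once, so it leaves open which of the two goes with the lower number; an open-chain group such as n-butyl, a 2-methoxyethyl group or a larger ring such as cyclopentyl on the same nitrogen would begin to separate them. Also open, from the compounds shown here alone, is whether the chloro change, seen with 2-hydroxyethyl on the nitrogen as a 3.1-fold higher number from compound 1 to compound 2 (0.48 log units; beyond the scatter), moves the number the same way with cyclobutyl in that place.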